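This account rests on a few compounds, and the source may have more. Where it says the series, first, only, none or still open, it means among the compounds named here.

Measured compounds:
- compound 1, `O=C1NC(=O)/C(=C/c2ccc(OCN3C(=O)c4ccccc4C3=O)c([N+](=O)[O-])c2)S1`: in an assay on isolated protein for inhibition of Alpha glucosidase (Homo sapiens), read by spectrophotometry, with stated times of 15 min and 30 min (a higher number here means a weaker inhibitor, a lower number a stronger inhibitor), compound 1 gives 22500 nM
- compound 2, `CCOc1cc(/C=C2\SC(=S)NC2=O)ccc1OCN1C(=O)c2ccccc2C1=O`: compound 2 gives 7720 nM
- compound 3, `O=C1NC(=S)S/C1=C\c1ccc(OCN2C(=O)c3ccccc3C2=O)cc1`: compound 3 gives 7910 nM

Among the three numbers in this assay, compound 3 stands second highest. Among the compounds with values here, its nearest neighbour is compound 2, and the two are within the scatter of each other; the only single-point step recorded, a 1.0-fold higher number from compound 2 to compound 3 (0.01 log units; within the scatter), is correspondingly flat. Within the data shown here, the highest number of the set belongs to compound 1, which differs from compound 3 in its core as well as in its substitution, so no single step links the two.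

Compound 4, `O=C1NC(=S)S/C1=C\c1ccc(OCN2C(=O)c3ccccc3C2=O)c([N+](=O)[O-])c1`, is reached from compound 3 by one change: nitro in place of hydrogen on an aromatic carbon. Among the measured compounds shown here, no measured step bears directly on this change. For the measured compounds named here, the flat step from compound 2 to compound 3 concerns a different group at a different position, and compound 1, the only measured compound carrying a nitro, cannot be read as a clean comparison because its core also differs. What compound 1 and compound 3 show is simply that the nitro-bearing compound has the higher number.

On that thin basis, compound 4 is expected to give a somewhat higher number than compound 3, with a 1.5-fold higher number from compound 3 to compound 4 (0.18 log units; within the scatter) as the estimated step, though a result within the scatter would not surprise. The estimate for compound 4 in this assay is 12000 nM, with a range from 4000 nM to 35000 nM.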

Compound 4, half-maximal inhibitory concentration: 6590 nM
Compound 4: the middle estimate sits 1.8-fold (0.26 log units) above what was measured; measured number inside the range.
By their numbers in this assay, from the lowest: compounds 4, 2 and 3 (each within the scatter of the next); then compound 1.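

In this assay, nitro on this aromatic carbon, ortho to a large group, brought no change beyond the scatter, whether it replaced hydrogen, a 1.2-fold lower number from compound 3 to compound 4 (0.08 log units; within the scatter), or ethoxy, a 1.2-fold lower number from compound 2 to compound 4 (0.07 log units; within the scatter), so these three groups could not be told apart at this position on the shared core. With nitro held in place, the difference appeared at the other site instead: a 3.4-fold lower number from compound 1 to compound 4 (0.53 log units; beyond the scatter), a modest step in which the group of 8 heavy atoms with 2 sulfur replaced the one with 2 oxygen and 1 sulfur, which shows that the high number of compound 1 does not go with nitro as such. No supporting measurement bears on why either result came out as it did.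

The compounds shown leave open whether an amine or a carboxylic acid on this carbon would also stay within the scatter of these three groups. They also leave open whether the step between the two five-membered ring groups keeps its size when hydrogen or ethoxy, rather than nitro, sits on this carbon.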